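Moving the Hydroxyl on a Shared Dienone Core

A few compounds are considered here, and "the series" means these few. Any claim that something is new, unique, unknown or untested is made for them only; others in the source may bear on it.

Within the data shown here, compound 1 `O=C1/C(=C/c2ccccc2)CCC/C1=C\c1ccc(O)cc1` is the only member of this small set that carries a number: in an assay on isolated protein for inhibition of Alpha glucosidase (Homo sapiens), with stated times of 5 min and 15 min (a lower number here means a stronger inhibitor, a higher number a weaker inhibitor), compound 1 gives 42300 nM. Compound 2 `O=C1/C(=C/c2ccccc2)CCC/C1=C\c1ccc(F)cc1` in this assay gives "not determined" (no result reported). Compound 3 `O=C1/C(=C/c2ccccc2)CCC/C1=C\c1ccc(Br)cc1` in this assay gives "not determined" (no result reported), so compound 3 stands with no value at all, and compound 2 likewise gives none. The step to compound 4 `O=C1/C(=C/c2ccccc2)CCC/C1=C\c1cccc(O)c1` puts (3-hydroxyphenyl in place of 4-bromophenyl on a double-bonded chain carbon bound to a double-bonded ring carbon). Among the measured compounds shown here, no measured pair traces this change, so the size or direction of the step in this assay cannot be drawn from the data. Because compound 1 gives 42300 nM in this assay, compound 4 is expected to land in a similarly weak range, around 40000 nM, with a plausible span from 10000 nM to 150000 nM.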

Compound 4, half-maximal inhibitory concentration: 28400 nM
Estimate against measurement, compound 4: 1.4-fold (0.15 log units) above, and the stated range covers the measured number.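

In this assay, 3-hydroxyphenyl in place of 4-hydroxyphenyl gives a 1.5-fold lower number from compound 1 to compound 4 (0.17 log units; within the scatter) and so the two compounds cannot be told apart. This first readable pair shows that, at this place on a double-bonded chain carbon bound to a double-bonded ring carbon, moving the hydroxyl makes no difference beyond the usual scatter. Nothing available explains this result.

Steps involving compound 2 or compound 3 cannot be read, so whether a hydroxyl matters here compared with fluorine or bromine stays unknown. Going by these compounds, how an amine or a carboxylic acid on this phenyl ring would behave also remains open.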